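Working notes: compound 2 to compound 3

The source may report more compounds than this note shows. Statements on the series, on what has been measured and on what is new or still open speak of the compounds shown alone.

In a physicochemical assay for solubility, read by nephelometry, in phosphate buffer, measured as kinetic solubility, with a stated time of 30 min, at pH 6.5 (on this read-out lower numbers stand for lower solubility and higher numbers for higher solubility), compound 1 (`O=C(O)CCCCOc1ccc([C@H]2CC[C@]3(CC2)OOC2(O3)C3CC4CC(C3)CC2C4)cc1`) reads < 1.6 ug/mL as a limit, not a number. Compound 2 (`O=C(O)CCCOc1ccc([C@H]2CC[C@]3(CC2)OOC2(O3)C3CC4CC(C3)CC2C4)cc1`) reads < 3.1 ug/mL as a limit too, so it has no firm position in the series. Compound 3 (`O=C(O)c1ccc([C@H]2CC[C@]3(CC2)OOC2(O3)C3CC4CC(C3)CC2C4)cc1`) has carboxy in place of 3-carboxypropoxy on an aromatic carbon, para to a large group (carboxy in place of 3-carboxypropoxy on an aromatic carbon). For the measured compounds named here, the only measured step that bears on this change is a step that the two limits leave unreadable from compound 1 to compound 2 and it offers no size or direction to carry over. Taking compound 2 at < 3.1 ug/mL as a limit, a small upward step in this assay is expected on weak grounds, and it may stay within the scatter. The estimated change is an at least 1.6-fold higher number from compound 2 to compound 3 (0.20 log units; that floor lies within the scatter). For compound 3 the expected value is 5 ug/mL with an estimated range from 1.5 ug/mL to 25 ug/mL and a real chance of another limit.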

Compound 3, solubility: < 3.1 ug/mL
Compound 3: a limit, no number; the forecaster's own chance of this, stated with the estimate: 45%; middle value at least 1.6-fold (0.20 log units) from the limit.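

In this assay, for the compounds shown here, compound 1, compound 2 and compound 3 all stand as limits, not numbers, so no step among them can be read. The compounds shown leave open whether carboxy, 3-carboxypropoxy and 4-carboxybutoxy differ at all on this read-out, and in which direction.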